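Swapping the sulfonyl aryl group in a benzoxazole sulfonamide series

This account rests on a few compounds, and the source may have more. Where it says the series, first, only, none or still open, it means among the compounds named here.

Measured compounds:
- compound 1 `O=S(=O)(Nc1ccc2oc(-c3ccccc3)nc2c1)c1ccc(Cl)c(Cl)c1`: 71000 nM in an ADME assay on HEK293 cells (Homo sapiens) for cytotoxicity, read by resazurin assay, with a stated time of 48 h; on this read-out higher numbers stand for lower toxicity in this test and lower numbers for higher toxicity in this test
- compound 2 `O=S(=O)(Nc1ccc2oc(-c3ccccc3)nc2c1)c1ccc(Cl)c(C(F)(F)F)c1`: 66000 nM
- compound 3 `CCc1ccc(S(=O)(=O)Nc2ccc(-c3nc4ccccc4o3)cc2)cc1`: 82000 nM

All three numbers lie close together. Compound 1 stands second highest of the three, and its gaps to the other two are both within the scatter, so no order among them can be read. Going by the values given here, the only single-point step among them, a 1.1-fold lower number from compound 1 to compound 2 (0.03 log units; within the scatter), changed nothing beyond the scatter.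

Compound 4 `COc1ccc(S(=O)(=O)Nc2ccc3oc(-c4ccccc4)nc3c2)cc1` has not yet been measured. Its difference from compound 1 is 4-methoxyphenyl in place of 3,4-dichlorophenyl on a sulfonyl sulfur. Among the compounds with values here, no measured step swaps the whole ring on the sulfonyl sulfur, so none bears on this change directly. Within the data shown here, the one step that touches that ring, a 1.1-fold lower number from compound 1 to compound 2 (0.03 log units; within the scatter), stayed within the scatter, and compound 3, which carries a different group on its sulfonyl sulfur and a differently attached core, gives 82000 nM, again within the scatter of compound 1. The expectation for compound 4 is therefore a step of about a 1.1-fold higher number from compound 1 to compound 4 (0.02 log units; within the scatter), that is, no change beyond the scatter. Compound 4 is estimated at 75000 nM, with a range from 40000 nM to 140000 nM.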

Compound 4, half-maximal cytotoxic concentration: 91000 nM
Compound 4: middle estimate off by 1.2-fold (0.08 log units), on the low side; measured number inside the range.
By their numbers in this assay, from the lowest: compounds 2, 1, 3 and 4 (each within the scatter of the next).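

The earlier step at this position replaced only one chloro with trifluoromethyl, while this change replaces the whole aryl group on the sulfonyl sulfur, and in this assay it gives a 1.3-fold higher number from compound 1 to compound 4 (0.11 log units; within the scatter). Both chlorine atoms leave and a methoxy group enters, so a larger change at this position than the earlier one still produces no difference beyond the scatter, which means that, for these two groups, the choice of ring has no readable effect on the number in this test. No supporting measurement is available to explain why the reading holds steady across this swap.

On these data alone, what remains open is whether any group on the sulfonyl sulfur can move this number beyond the scatter in either direction, since the rings compared here are both substituted phenyl rings. A carboxylic acid or an amine on that ring, or a plain alkyl chain in place of the ring, could show whether the flat picture extends beyond aryl groups of this kind.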